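Aryl swap from compound 2 to compound 3: working notes

The source may hold more compounds than are shown below. What is called first, only, known or untested is meant among the compounds shown, and "the series" means these compounds.

Measured so far in an ADME assay on Vero cells (Chlorocebus sabaeus) for cytotoxicity, read by neutral red uptake, tested at 12.3 ug/mL; on this read-out lower numbers stand for a stronger effect and higher numbers for a weaker effect at the one concentration tested:
- compound 1, `O=C1CSC(c2ccccc2[N+](=O)[O-])N1CCN1CCCCC1`, gives 100%
- compound 2, `O=C1CSC(c2cccc(F)c2)N1CCN1CCCCC1`, gives 100%

Compound 1 and compound 2 stand level at the digits shown in this assay; the two values lie within the usual scatter of one another, so nothing separates them and no order can be read from them. Both sit at the top of the read-out, which on this scale means the weakest effect that the assay registers at the single concentration tested.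

Compound 3, `O=C1CSC(c2ccccc2Cl)N1CCN1CCCCC1`, has not yet been measured in this assay. Against compound 2 it differs in one place: 2-chlorophenyl in place of 3-fluorophenyl on a saturated ring carbon. Going by the values given here, no step between two measured compounds covers this pair, so there is nothing in the numbers to size the change from; what is known is only that compound 1 and compound 2, which differ in the same region of the molecule, gave the same figure.

On that basis the step from compound 2 to compound 3 is expected to be no change at the digits printed from compound 2 to compound 3 (within the scatter), that is none beyond the scatter. For compound 3 the value in this assay is therefore estimated at 100%, with a range from 88% to 108%.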

Compound 3, a percentage reported as activity, at one concentration (the size of the read-out at that concentration, not a potency): 100%
For compound 3 middle estimate and measured number coincide at the digits printed; measured number inside the range.
By their numbers in this assay, from the lowest: compounds 1, 2 and 3 (each within the scatter of the next).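

In this assay, 2-chlorophenyl in place of 3-fluorophenyl on a saturated ring carbon gives no change at the digits printed from compound 2 to compound 3 (within the scatter), and chloro in place of nitro on an aromatic carbon gives no change at the digits printed from compound 1 to compound 3 (within the scatter). Going by these compounds alone, the second step is the first to isolate the substituent on the aromatic ring with the rest of the molecule held constant, so chloro and nitro can now be compared directly, and this comparison does not separate them. Fluoro, chloro and nitro on the aromatic ring therefore all leave the read-out at the top of the scale in these compounds, although the fluoro compound differs from the other two in more than the identity of the substituent, and nothing on hand offers a reason for this flat reading.

As far as these compounds go, whether an amine, a carboxylic acid or a methoxy group on the aromatic ring would bring the reading away from the top of the scale remains open, as does the effect of a longer alkyl chain in place of the aryl group. With a single tested concentration, the three compounds also cannot be told apart at any other concentration.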